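Adding a carboxy group to an anilide: crossing the membrane

The compounds below may be only part of what the source reports. "The series", "measured", "known", "first", "only" and "open" are said of these compounds alone.

Measured compounds:
- compound 1 `O=C(Nc1nc(-c2cccc(F)c2)cs1)c1cc([N+](=O)[O-])ccc1Cl`, 3 10^-6 cm/s
- compound 2 `COc1cc(Cl)c(C(=O)Nc2cccc(-c3nc4ccccc4s3)c2)cc1[N+](=O)[O-]`, 12 10^-6 cm/s

Of the compounds shown here, two have been measured in an ADME assay for permeability, using PAMPA, at pH 7.4; a higher number here means that the compound crosses the layer faster, a lower number that the compound crosses the layer more slowly. Compound 2 gives 12 10^-6 cm/s, the higher of the two numbers, while compound 1 gives 3 10^-6 cm/s, a gap that lies beyond the usual scatter of this assay.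

Compound 3 `O=C(O)COc1cc(Cl)c(C(=O)Nc2cccc(-c3nc4ccccc4s3)c2)cc1[N+](=O)[O-]` is not yet measured. It differs from compound 2 in one place:

carboxy in place of hydrogen on a saturated chain carbon bound to an oxygen on an aromatic ring

Among the measured compounds shown here, no pair of measured compounds shows a step of this kind, so there is no measured step to lean on. From compound 2 to compound 3 the step is expected to be a drop, and a clear one, beyond the scatter: an 8.0-fold lower number from compound 2 to compound 3 (0.90 log units; beyond the scatter). Compound 3 is therefore estimated at 1.5 10^-6 cm/s, with a plausible range from 0.3 10^-6 cm/s to 6 10^-6 cm/s.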

Compound 3, apparent permeability in the ADME assay: < 1 10^-6 cm/s
Compound 3 was reported as a limit; the forecaster's own chance of this, stated with the estimate: 15%; middle value at least 1.5-fold (0.17 log units) from the limit.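

In the ADME assay, changing methoxy to carboxymethoxy gives an at least 12-fold lower number from compound 2 to compound 3 (1.07 log units; beyond the scatter), so this position does not tolerate the carboxy group without a large loss in this read-out. The size of that step is only a minimum, as compound 3 was reported as a limit: the limit of < 1 10^-6 cm/s in the ADME assay, at which 1 of the 3 values shown sits. In a physicochemical assay for solubility, read by spectrophotometry, in phosphate buffer, measured as kinetic solubility, with a stated time of 18 h, at pH 7.4 (on this read-out higher numbers stand for higher solubility and lower numbers for lower solubility), compound 2 gives 10 nM and compound 3 gives 6700 nM, which shows that the same single change lowers one read-out while raising the other: the measured solubility of compound 2, 10 nM, and of compound 3, 6700 nM, a 670-fold higher number (2.83 log units; beyond the scatter)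

As far as these compounds go, it stays open whether an amine or a primary amide in place of the carboxy, or a longer chain carrying the carboxy, would shift the two read-outs by different amounts. From the compounds shown here alone, the actual number for compound 3 in the ADME assay also stays open.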